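This account rests on a few compounds, and the source may have more. Where it says the series, first, only, none or still open, it means among the compounds named here.

Measured so far in a functional assay for agonist activity at G protein-coupled receptor 88 (Homo sapiens), read by HTRF and cAMP accumulation; on this read-out lower numbers stand for an effect already at smaller amounts and higher numbers for an effect only at larger amounts of compound:
Compound 1, `CC[C@H](C)[C@H](N)CN(C(=O)[C@@H]1C[C@H]1c1ccc(Cl)cc1)c1ccc(-c2ccccc2)cc1`, gives 4300 nM.
Compound 2, `CC[C@H](C)[C@H](N)CN(C(=O)[C@@H]1C[C@H]1c1cccc(OC)c1)c1ccc(-c2ccccc2)cc1`, gives 3000 nM.
Compound 3, `CC[C@H](C)[C@H](N)CN(C(=O)[C@@H]1C[C@H]1c1ccccn1)c1ccc(-c2ccccc2)cc1`, gives 130 nM.

Among these three, compound 3 stands at the lowest number. The step of a 33-fold lower number from compound 1 to compound 3 (1.52 log units; beyond the scatter) and the step of a 23-fold lower number from compound 2 to compound 3 (1.36 log units; beyond the scatter) are both large and reach beyond the usual scatter, whereas the step of a 1.4-fold lower number from compound 1 to compound 2 (0.16 log units; within the scatter) stays within it. The two substituted phenyl rings on the saturated ring carbon thus end up close to each other, and only the pyridin-2-yl ring sets compound 3 apart.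

Compound 4, `CC[C@H](C)[C@H](N)CN(C(=O)[C@@H]1C[C@H]1c1csc(C)n1)c1ccc(-c2ccccc2)cc1`, is not yet measured. It differs from compound 3 in one place: 2-methyl-1,3-thiazol-4-yl in place of pyridin-2-yl on a saturated ring carbon. The measured steps that bear on this change are the two that placed a nitrogen-containing aromatic ring on this carbon, a 33-fold lower number from compound 1 to compound 3 (1.52 log units; beyond the scatter) and a 23-fold lower number from compound 2 to compound 3 (1.36 log units; beyond the scatter), both large. Among the compounds with values here, no measured pair, however, shows what happens when one nitrogen-containing aromatic ring is exchanged for another. The change keeps such a ring at the same position, so a swing as large as those two steps, in either direction, seems less likely than a modest one, possibly toward a higher number. The expected step is a 2.3-fold higher number from compound 3 to compound 4 (0.36 log units; beyond the scatter). Compound 4 is estimated at 300 nM, in a range from 90 nM to 1000 nM.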

Compound 4, half-maximal effective concentration: 1500 nM
Beside the measured number, compound 4's estimate is 5.0-fold (0.70 log units) below it, outside the stated range (above it).
By their numbers in this assay, from the lowest: compound 3; then compounds 4, 2 and 1 (each within the scatter of the next, the first and the last beyond it).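

In this assay, the step of a 12-fold higher number from compound 3 to compound 4 (1.06 log units; beyond the scatter) shows that a nitrogen-containing aromatic ring on this saturated ring carbon is not enough to keep the low number of compound 3. The 2-methyl-1,3-thiazol-4-yl ring instead brings the number back toward those of the substituted phenyl rings, with a 2.0-fold lower number from compound 2 to compound 4 (0.30 log units; within the scatter) staying within the scatter and a 2.9-fold lower number from compound 1 to compound 4 (0.46 log units; beyond the scatter) being only a modest step. Among these four compounds, pyridin-2-yl alone stands clearly apart, and no measurement at hand gives a reason for this.

The exchange swaps a six-membered ring for a five-membered one, adds a sulfur atom and brings in a methyl group all at once, so these compounds cannot show which of these differences matters. The plain 1,3-thiazol-4-yl ring without its methyl group would separate the methyl group from the ring itself, and pyridin-3-yl would test whether the low number depends on where the nitrogen sits in the six-membered ring.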